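Sulfonamide series: nitrile to oxadiazolylmethyl, permeability notes

The source may report more compounds than this note shows. Statements on the series, on what has been measured and on what is new or still open speak of the compounds shown alone.

Measured so far:
compound 1, `N#CCCN([C@H](CCC(F)(F)F)C(N)=O)S(=O)(=O)c1ccc(Cl)cc1`, 10.2 10^-6 cm/s
compound 2, `N#C[C@H]1CC[C@H](CN([C@H](CCC(F)(F)F)C(N)=O)S(=O)(=O)c2ccc(Cl)cc2)CC1`, 15.7 10^-6 cm/s; 14.6 10^-6 cm/s (2 entries)

Among the compounds with values here, in an ADME assay on MDCKII-LE cells (Canis lupus familiaris) for permeability (on this read-out higher numbers stand for higher permeability and lower numbers for lower permeability), compound 1 gives the only single number of the pair, and the entries for compound 2 lie within the usual scatter of it, so the two show no difference worth reading; the repeat entries of compound 2 (the several entries of compound 2 in this assay, 15.7 10^-6 cm/s; 14.6 10^-6 cm/s (2 entries)) only mark how close repeated runs of this kind can sit.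

Compound 3, `NC(=O)[C@@H](CCC(F)(F)F)N(CCCc1ncon1)S(=O)(=O)c1ccc(Cl)cc1`, is not yet measured. Against compound 1 the counted change is (1,2,4-oxadiazol-3-yl)methyl in place of cyano on a saturated chain carbon, two bonds along the chain from a sulfonamide nitrogen. Within the data shown here, no pair of measured compounds shows this change, so nothing fixes its size or direction. The expected step from compound 1 to compound 3 in this assay, a 1.3-fold lower number from compound 1 to compound 3 (0.11 log units; within the scatter), is therefore taken as small, at most on the edge of the scatter and leaning slightly downward. On that basis compound 3 is estimated at 8 10^-6 cm/s, with a range from 4 10^-6 cm/s to 16 10^-6 cm/s.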

Compound 3, apparent permeability: 31.3 10^-6 cm/s
Estimate against measurement, compound 3: 3.9-fold (0.59 log units) below; measured number outside the range, above it.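

In this assay, (1,2,4-oxadiazol-3-yl)methyl in place of cyano on a saturated chain carbon, two bonds along the chain from a sulfonamide nitrogen, gives a 3.1-fold higher number from compound 1 to compound 3 (0.49 log units; beyond the scatter). Within the data shown here, this is the first reading of this change, and for this one pair it sets the direction as upward, with the swap from a group with no ring to a five-membered aromatic ring costing nothing on this read-out. Repeat runs in this assay sit close together, so a step of this size is hard to put down to run-to-run spread: the several entries of compound 2 in this assay, 15.7 10^-6 cm/s; 14.6 10^-6 cm/s (2 entries)

One pair cannot say whether the step belongs to the aromatic ring or simply to the larger group. A longer chain ending in the nitrile, or an amine or a carboxylic acid on the same chain carbon, would help separate the two.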